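The source may report more compounds than this note shows. Statements on the series, on what has been measured and on what is new or still open speak of the compounds shown alone.

Measured so far in a functional assay on the whole organism (Tail, strain ICR) with Mus musculus as the target, in the tail flick test, with a stated time of 30 min, at a dose of 25 umol/kg by the oral route; a lower number here means a weaker effect, a higher number a stronger effect of the compound at the dose given:
Compound 1 `N=C(N)NCCC[C@H](NC(=O)CN(c1ncnc2c1ncn2C1CCCCO1)C1CC1)C(=O)OCc1ccccc1` gives 34.3%.
Compound 2 `C[C@H](NC(=O)CN(c1nc(Cl)nc2[nH]cnc12)C1CC1)C(=O)O` gives 48.1%.

Of these two numbers, compound 1 stands lowest; the nearer value is that of compound 2, and the gap between them lies beyond the usual scatter. Compound 3 `CC(C)[C@H](NC(=O)CN(c1ncnc2c1ncn2C1CCCCO1)C1CC1)C(=O)OCc1ccccc1` is not yet measured. It differs from compound 1 by a group of 3 heavy atoms (3 carbon; no ring) in place of a group of 7 heavy atoms (4 carbon, 3 nitrogen; no ring), on a saturated chain carbon bound to an amide-type nitrogen and a carbonyl carbon. For the measured compounds named here, no measured pair shows this change, so its size is unknown; a shift staying within the scatter, in no clear direction, is expected. Compound 3 is estimated at 36% in this assay, between 15% and 58%. The expected step is a number 1.7 percentage points higher from compound 1 to compound 3 (within the scatter).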

Compound 3, a percentage reported as activity, at one dose (the size of the read-out at that dose, not a potency): 21.8%
Estimate against measurement, compound 3: 14.2 percentage points above; measured number inside the range.
By their numbers in this assay, from the lowest: compound 3; then compound 1; then compound 2.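

In this assay, the saturated chain carbon bound to an amide-type nitrogen and a carbonyl carbon proves sensitive to its substituent: putting isopropyl in place of the group of 7 heavy atoms gives a number 12.5 percentage points lower from compound 1 to compound 3 (beyond the scatter) with the rest of the structure unchanged. For the compounds shown here, this is the first step that can be read at this place. Nothing measured here bears on why the number falls.

From the compounds shown here alone, whether an amine or a longer alkyl chain on this carbon would stand nearer to compound 1 or compound 3 remains open. So does whether the step keeps its direction on another core.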